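Para substituent swap on the ester series: methyl to chloro

The compounds below may be only part of what the source reports. "The series", "measured", "known", "first", "only" and "open" are said of these compounds alone.

Compound 1 `CCOC(=O)C1=Cc2ccccc2OC1(OCc1cc(-c2ccc(C)cc2)no1)C(F)(F)F`: in a functional assay on A549 cells (Homo sapiens) for inhibition, read by MTT assay, with a stated time of 24 h (on this read-out higher numbers stand for weaker inhibition and lower numbers for stronger inhibition), compound 1 gives > 150000 nM, which is a limit of the assay and not a number.
Compound 2 `Cc1ccc(-c2cc(COC3(C(F)(F)F)Oc4ccccc4C=C3C(=O)O)on2)cc1`: in this assay compound 2 gives 51200 nM.
Compound 3 `CCOC(=O)C1=Cc2ccccc2OC1(OCc1cn(-c2ccccc2)nn1)C(F)(F)F`: in this assay compound 3 gives > 150000 nM, again a limit of the assay.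

Compound 1 therefore stands at the edge of what this assay can report; two of the three values shown sit there (the limit of > 150000 nM in this assay, at which 2 of the 3 values shown sit). Within the data shown here, the only measured step with a number at both ends is an at least 2.9-fold lower number from compound 1 to compound 2 (0.46 log units; beyond the scatter), hydrogen in place of ethyl on an oxygen next to a carbonyl group. It concerns the ester, not the aryl ring.

Compound 4 `CCOC(=O)C1=Cc2ccccc2OC1(OCc1cc(-c2ccc(Cl)cc2)no1)C(F)(F)F` differs from compound 1 by chloro in place of methyl on an aromatic carbon, para to a large group, or 4-methylphenyl to 4-chlorophenyl. Among the measured compounds shown here, no measured step touches that ring. Compound 3 carries a different ring in the same place, and its value is likewise a limit, so no direction is shown for changes at this part of the core. Compound 4 keeps the ethyl ester of compound 1, the feature that an at least 2.9-fold lower number from compound 1 to compound 2 (0.46 log units; beyond the scatter) ties to the weaker end.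

Expected for compound 4 is no step beyond the scatter, a number no higher from compound 1 to compound 4 (the limit leaves the size open), most likely again a limit. The estimate for compound 4 is 150000 nM, with a range from 60000 nM to 400000 nM.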

Compound 4, half-maximal inhibitory concentration: 19100 nM
Beside the measured number, compound 4's estimate is 7.9-fold (0.90 log units) above it, and the stated range ends above it.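

Among these compounds, the change from 4-methylphenyl to 4-chlorophenyl moves the read-out in this assay, with an at least 7.8-fold lower number from compound 1 to compound 4 (0.89 log units; beyond the scatter), so this place on the aromatic ring, which no earlier step touched, is not silent while the ethyl ester stays in place. The ethyl ester therefore does not by itself hold a compound at the weak end of the series, and compound 4, at 19100 nM, is the first ethyl ester shown with a number and not a limit. The true size of the step stays open, since the value of compound 1 is a limit of the assay and not a number: the limit of > 150000 nM in this assay, at which 2 of the 4 values shown sit.

Only one swap at this place is shown, so it remains open whether the effect is particular to chloro or would also appear with fluoro, methoxy or an amine there. Also open, from the compounds shown here alone, is what a carboxylic acid carrying the 4-chlorophenyl group would give in this assay, and so whether the change on the ring and the change at the ester add up.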